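The compounds below may be only part of what the source reports. "The series", "measured", "known", "first", "only" and "open" are said of these compounds alone.

Measured compounds:
Compound 1, `COc1ccccc1C(=O)Nc1[nH]nc(-c2ccccn2)c1C1CC1`: > 100 mL.min-1.g-1, which is a limit of the assay rather than a number.
Compound 2, `N#Cc1ccc(OC2CCN(C(=O)Nc3cc(-c4ccccn4)n[nH]3)CC2)cc1`: 30.8 mL.min-1.g-1.

Both were tested in an ADME assay on liver (Mesocricetus auratus) for metabolic stability, using microsomes; on this read-out higher numbers stand for fast clearance and lower numbers for slow clearance. Compound 1 stands only at a limit in this assay, (the limit of > 100 mL.min-1.g-1 in this assay, at which 1 of the 2 values shown sits), so no exact number is known for it. Compound 2 gives a plain number in this assay, and nothing is given here on how compound 2 and compound 1 relate structurally as a single step.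

Compound 3 is `O=C(Nc1[nH]nc(-c2ccccn2)c1C1CC1)c1ccccc1F`. It differs from compound 1 by fluoro in place of methoxy on an aromatic carbon. Among the compounds with values here, no measured pair here shows what this change does in this assay, and because compound 1 sits at a limit (the limit of > 100 mL.min-1.g-1 in this assay, at which 1 of the 2 values shown sits), the starting point itself is uncertain. The expected step from compound 1 to compound 3 is an at least 1.6-fold lower number from compound 1 to compound 3 (0.22 log units; that floor lies within the scatter), a move toward slower clearance, though it may not reach beyond the scatter. For compound 3 in this assay the estimate is 60 mL.min-1.g-1, with a likely range from 25 mL.min-1.g-1 to 150 mL.min-1.g-1.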

Compound 3, intrinsic clearance in microsomes: > 100 mL.min-1.g-1
Compound 3: a limit, no number (the forecaster's own chance of this, stated with the estimate: 35%); at least 1.6-fold (0.22 log units) between middle value and limit.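

Compound 1 and compound 3 both sit at a limit rather than at a number in this assay, so no step from compound 1 to compound 3 can be read: the limit of > 100 mL.min-1.g-1 in this assay, at which 2 of the 3 values shown sit.

The compounds shown leave open whether going from 2-methoxyphenyl to 2-fluorophenyl changes clearance at all, and by how much.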